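Swapping chloro for fluoro in a series of aorta relaxants

A few compounds are considered here, and "the series" means these few. Any claim that something is new, unique, unknown or untested is made for them only; others in the source may bear on it.

Measured compounds:
- compound 1 `CC(C)NC1=NS(=O)(=O)c2cc(Cl)ccc2N1` gives 36300 nM
- compound 2 `CC(C)NC1=NS(=O)(=O)c2cc(F)ccc2N1` gives 43100 nM
- compound 3 `CCNC1=NS(=O)(=O)c2cc(F)c(Cl)cc2N1` gives 42400 nM

All three compounds were tested in a functional assay (aorta) with Rattus norvegicus as the target, with a stated time of 90 min, at 37 degrees C; on this read-out lower numbers stand for an effect already at smaller amounts and higher numbers for an effect only at larger amounts of compound. Compound 1 and compound 2 differ in one place only: fluoro in place of chloro on an aromatic carbon. This change gave a 1.2-fold higher number from compound 1 to compound 2 (0.07 log units; within the scatter), so the two compounds cannot be told apart on this read-out.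

Compound 3 carries a different core; how it differs from the core of compound 1 is not broken down here. Its value sits close to that of compound 2, and these two likewise cannot be separated within the scatter.

Compound 4 `CCNC1=NS(=O)(=O)c2cc(F)c(F)cc2N1` has not yet been measured. It differs from compound 3 by the same kind of change as that from compound 1 to compound 2: fluoro in place of chloro on an aromatic carbon. The surroundings are not identical, since in compound 4 the new fluoro group sits ortho to a fluoro group, which is not the case in compound 2. Within the data shown here, still, the one measured example of this kind of change gave a 1.2-fold higher number from compound 1 to compound 2 (0.07 log units; within the scatter), and nothing in the data points to a different outcome here.

Compound 4 is therefore expected to show a 1.2-fold higher number from compound 3 to compound 4 (0.07 log units; within the scatter). Compound 4 is estimated at 50000 nM, with a likely range from 25000 nM to 100000 nM.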

Compound 4, half-maximal effective concentration: 66700 nM
The estimate for compound 4 lay 1.3-fold (0.13 log units) below the measured number; the measured number falls inside the stated range.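

In this assay, fluoro in place of chloro on an aromatic carbon of the core of compound 3 gave a 1.6-fold higher number from compound 3 to compound 4 (0.20 log units; within the scatter), so this step, like the earlier one, is too small to tell the two compounds apart. Set side by side, the two examples of the change cannot be told apart either: the same change on two cores in this assay, a 1.2-fold higher number (0.07 log units; within the scatter) from compound 1 to compound 2 and a 1.6-fold higher number (0.20 log units; within the scatter) from compound 3 to compound 4, 1.3-fold (0.12 log units) apart, within the scatter of two such steps. This shows that on these two cores the swap behaves alike, leaving the number within the usual scatter, even though in compound 4 the new fluoro group sits ortho to a fluoro group; it does not show that the swap would stay this small on every core of the series, since two small steps are a thin basis and cannot reveal a modest difference hidden in the scatter.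

The compounds shown leave open whether a different group on that aromatic carbon, such as methoxy, trifluoromethyl or a nitrile, would move the number beyond the scatter. They also leave open what a longer chain, such as butyl, or a ring such as cyclopentyl, would do in place of the chains on the amine nitrogen of these compounds.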